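The compounds below may be only part of what the source reports. "The series", "measured", "known", "first", "only" and "open" are said of these compounds alone.

Compound 1 `C[n+]1ccn(CCCC#N)c1/C=N/O` gives < -3 in a physicochemical assay for lipophilicity (on this read-out higher numbers stand for higher lipophilicity and lower numbers for lower lipophilicity), which is a limit of the assay rather than a number (the limit of < -3 in this assay, at which 1 of the 2 values shown sits). Compound 2 `C[n+]1ccn(CCOCCF)c1/C=N/O` gives -2.62 in this assay, the only number shown in the series. Among the compounds with values here, the one measured step is a number at least 0.38 log units higher from compound 1 to compound 2 (beyond the scatter). Compound 3 `C[n+]1ccn(CCS(C)(=O)=O)c1/C=N/O` differs from compound 2 by methylsulfonyl in place of 2-fluoroethoxy on a saturated chain carbon, two bonds along the chain from an aromatic nitrogen. Within the data shown here, no measured step covers this exchange; the one step recorded rose when a 2-fluoroethoxy entered. A step of a number 0.48 log units lower from compound 2 to compound 3 (beyond the scatter) is expected, downward, with a fair chance that the assay again returns only a limit. For compound 3 the estimate in this assay is -3.1, between -3.6 and -2.7.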

Compound 3, distribution coefficient: -3.5
Beside the measured number, compound 3's estimate is 0.40 log units above it, and the stated range covers the measured number.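

In this assay, this position on a saturated chain carbon, two bonds along the chain from an aromatic nitrogen, now shows a fall as well as a rise: methylsulfonyl in place of 2-fluoroethoxy gives a number 0.88 log units lower from compound 2 to compound 3 (beyond the scatter). Both groups hold 4 heavy atoms, so this step comes with no change in that count. Compound 1 gives < -3, which is a limit and not a number, so its step to compound 3 cannot be read.

As far as these compounds go, whether the fall depends on the sulfur or on its two oxygens remains open. Also open, from the compounds shown here alone, is where an amine, a carboxylic acid or a longer chain carrying the methylsulfonyl would fall on this read-out.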